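A few compounds are considered here, and "the series" means these few. Any claim that something is new, unique, unknown or untested is made for them only; others in the source may bear on it.

Compound 1 `Cc1ccc(/C=C2\CCC/C(=C\c3ccc([N+](=O)[O-])cc3)C2=O)cc1` gives 8160 nM in a functional assay on L1210 cells (Mus musculus) for cytotoxicity, with a stated time of 48 h; a higher number here means a weaker inhibitor, a lower number a stronger inhibitor.
Compound 2 `COc1ccc(/C=C2\CCC/C(=C\c3ccc([N+](=O)[O-])cc3)C2=O)cc1` gives 240000 nM in this assay.
Compound 3 `COc1cc(/C=C2\CCC/C(=C\c3ccccc3[N+](=O)[O-])C2=O)cc(OC)c1OC` gives 1520 nM in this assay.

Compound 2 stands at the highest number of the three, its nearest neighbour being compound 1, its furthest compound 3. The one step that joins two of these compounds in a single place is a 29-fold higher number from compound 1 to compound 2 (1.47 log units; beyond the scatter), and it runs in the direction of a weaker inhibitor.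

Compound 4 `O=C1/C(=C/c2ccccc2)CCC/C1=C\c1ccc([N+](=O)[O-])cc1` has not yet been measured in this assay. It differs from compound 2 by hydrogen in place of methoxy on an aromatic carbon. For the measured compounds named here, no measured step shows this exact change, so the only guide is that compound 1, carrying methyl in the same position, sits far below compound 2 in number, as a 29-fold higher number from compound 1 to compound 2 (1.47 log units; beyond the scatter) shows. Removing the methoxy entirely is therefore expected to bring the number back down, though how far is open.

Compound 4 is expected to give about 15000 nM, within 3000 nM to 80000 nM. This estimate means a step of a 16-fold lower number from compound 2 to compound 4 (1.20 log units; beyond the scatter), expected to be beyond the scatter and toward a stronger inhibitor, because compound 1 at 8160 nM shows how much lower this position can read without methoxy.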

Compound 4, half-maximal inhibitory concentration: 9800 nM
Beside the measured number, compound 4's estimate is 1.5-fold (0.18 log units) above it; measured number inside the range.
By their numbers in this assay, from the lowest: compound 3; then compounds 1 and 4 (each within the scatter of the next); then compound 2.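

In this assay, removing the methoxy gives a 24-fold lower number from compound 2 to compound 4 (1.39 log units; beyond the scatter), so the high number of compound 2 now stands apart from two neighbours rather than one. Hydrogen and methyl at this place on the aromatic ring cannot be told apart, with a 1.2-fold higher number from compound 1 to compound 4 (0.08 log units; within the scatter). The earlier step from methyl to methoxy, a 29-fold higher number from compound 1 to compound 2 (1.47 log units; beyond the scatter), could not show whether methyl itself had lowered the number, but among compounds 1, 2 and 4 methyl offers no measurable gain over hydrogen, and only the methoxy compound stands apart.

No measurement given here speaks to why the methoxy behaves differently from hydrogen and methyl at this place. Going by these compounds, it remains open whether a hydroxyl, an ethoxy or an amine at the same place would read like the methoxy or like hydrogen, and whether the change from 4-methoxyphenyl to phenyl would have the same size on a core with the nitro group placed as in compound 3.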